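From phenyl to 2-chlorophenyl in compound 1

The source may report more compounds than this note shows. Statements on the series, on what has been measured and on what is new or still open speak of the compounds shown alone.

In a functional assay on K562 cells (Homo sapiens) for cytotoxicity, read by MTT assay, with a stated time of 48 h (a lower number here means a stronger inhibitor, a higher number a weaker inhibitor), compound 1 `CCOC(=O)[C@@]1(C(=O)Nc2ccccc2)C[C@@H]1c1cc(OC)c(OC)c(OC)c1` gives > 100000 nM, which is a limit of the assay and not a number. A further entry for compound 1 also gives no single number. Compound 3 `CCOC(=O)[C@@]1(C(=O)Nc2ccccc2Cl)C[C@@H]1c1cc(OC)c(OC)c(OC)c1` has chloro in place of hydrogen on an aromatic carbon, ortho to a large group, so phenyl becomes 2-chlorophenyl (chloro in place of hydrogen on an aromatic carbon). Compound 2 `CCOC(=O)C1(C(=O)Nc2ccccc2Cl)CC1c1cc(OC)c(OC)c(OC)c1` also carries 2-chlorophenyl and gives 41400 nM; 14200 nM (2 entries), so a clear gain in strength is expected in this assay. The expected change is an at least 4.0-fold lower number from compound 1 to compound 3 (0.60 log units; beyond the scatter). For compound 3 the estimated value is 25000 nM, with an expected range from 9000 nM to 70000 nM.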

Compound 3, half-maximal inhibitory concentration: 49400 nM
Compound 3: middle estimate off by 2.0-fold (0.30 log units), on the low side; the measured number falls inside the stated range.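

With both compounds drawn in the same defined configuration, the change from phenyl to 2-chlorophenyl can now be read directly in this assay as an at least 2.0-fold lower number from compound 1 to compound 3 (0.30 log units; that floor lies within the scatter). Compound 2 could not give this step: the fact that one of compounds 2 and 3 is drawn with a defined configuration and the other without, at the place where they differ. The step has only a floor, set by a limit of the assay: the limit of > 100000 nM in this assay, at which 1 of the 3 values shown sits. From the compounds shown here alone, whether a fluoro or a methoxy group in place of the chloro would give a lower number remains open. So does what a chloro elsewhere on the phenyl group would do.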